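Swapping ethoxycarbonyl for carboxy: what to expect

A few compounds are considered here, and "the series" means these few. Any claim that something is new, unique, unknown or untested is made for them only; others in the source may bear on it.

In an ADME assay on L929 cells (Mus musculus) for cytotoxicity, read by resazurin assay, with a stated time of 48 h (a lower number here means that less compound is tolerated, a higher number that more compound is tolerated), compound 1 (`O=c1c2cc([N+](=O)[O-])ccc2n(CCCBr)n1Cc1ccccc1`) reads 25200 nM and compound 2 (`COC(=O)Cn1c2ccc([N+](=O)[O-])cc2c(=O)n1Cc1ccccc1`) reads 129000 nM while compound 3 (`CCOC(=O)CCCn1c2ccc([N+](=O)[O-])cc2c(=O)n1Cc1ccccc1`) reads 78100 nM in the same test. Compound 3 is thus within the scatter of compound 2, and compound 1 lies clearly lower than both. Compound 4 (`O=C(O)CCCn1c2ccc([N+](=O)[O-])cc2c(=O)n1Cc1ccccc1`) carries hydrogen in place of ethyl on an oxygen next to a carbonyl group. For the measured compounds named here, no measured step makes this exact change. The nearest guides are a 5.1-fold higher number from compound 1 to compound 2 (0.71 log units; beyond the scatter) and a 3.1-fold higher number from compound 1 to compound 3 (0.49 log units; beyond the scatter) for replacing the bromo-bearing chain, while a 1.7-fold lower number from compound 2 to compound 3 (0.22 log units; within the scatter) shows how little changing the ester-bearing chain moved the number. A small upward step is expected in this assay, possibly within the scatter (a 1.4-fold higher number from compound 3 to compound 4 (0.15 log units; within the scatter)). Compound 4 is estimated at 110000 nM (expected range 45000 nM to 260000 nM).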

Compound 4, concentration lethal to 50% of the cells: > 256000 nM
Compound 4: only a limit was reported (the forecaster's own chance of this, stated with the estimate: 15%); at least 2.3-fold (0.36 log units) between middle value and limit.
By their numbers in this assay, from the lowest: compound 1; then compounds 3 and 2 (each within the scatter of the next). At a limit, above all of these: compound 4.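

In this assay compound 4 gives only a limit, not a true number: the limit of > 256000 nM in this assay, at which 1 of the 4 values shown sits. Exchanging ethyl for hydrogen on this oxygen, which turns the ester into a free carboxy group, gives an at least 3.2-fold higher number from compound 3 to compound 4 (0.51 log units; beyond the scatter), a change beyond the scatter, which the earlier step between the two esters was not. The wider comparisons read an at least 1.9-fold higher number from compound 2 to compound 4 (0.29 log units; that floor lies within the scatter) and an at least 10-fold higher number from compound 1 to compound 4 (1.00 log units; beyond the scatter).

On these data alone, the true size of these steps stays open, since the value for compound 4 is a limit. Also open, as far as these compounds go, is whether an amide, or a longer chain ending in carboxy, would read the same way.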